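The source may report more compounds than this note shows. Statements on the series, on what has been measured and on what is new or still open speak of the compounds shown alone.

Measured compounds in a functional assay on A549 cells (Homo sapiens) for antiproliferative activity, read by MTT assay, with a stated time of 72 h; a lower number here means a stronger inhibitor, a higher number a weaker inhibitor:
Compound 1 `COc1cc2ncnc(Nc3ccc(Cl)cc3)c2cc1OCCCCC(=O)Nc1ccc(S(N)(=O)=O)cc1` gives > 40000 nM, which is a limit of the assay and not a number.
Compound 2 `COc1ccccc1Nc1ncnc2cc(OC)c(OCCCCC(=O)Nc3ccc(S(N)(=O)=O)cc3)cc12` gives 24100 nM.
Compound 3 `COc1cc2ncnc(Nc3ccc(C(F)(F)F)cc3)c2cc1OCCCCC(=O)Nc1ccc(S(N)(=O)=O)cc1` gives 14800 nM.

Compound 3 has the lowest of the two numbers, but compound 2 sits within the scatter of it, so the two cannot be ranked. The value of compound 1 is only a limit, (the limit of > 40000 nM in this assay, at which 1 of the 3 values shown sits). Compound 4 `COc1cc2ncnc(Nc3ccccc3)c2cc1OCCCCC(=O)Nc1ccc(S(N)(=O)=O)cc1` has not yet been measured; it differs from compound 3 by hydrogen in place of trifluoromethyl on an aromatic carbon. Among the compounds with values here, two measured steps bear on this change. Putting trifluoromethyl in place of chloro on the aromatic carbon gave an at least 2.7-fold lower number from compound 1 to compound 3 (0.43 log units; beyond the scatter). Putting 4-(trifluoromethyl)phenyl in place of 2-methoxyphenyl gave a 1.6-fold lower number from compound 2 to compound 3 (0.21 log units; within the scatter). Removing the trifluoromethyl group altogether, leaving only hydrogen, is therefore expected to push the number upward, and the step is estimated as a 2.2-fold higher number from compound 3 to compound 4 (0.33 log units; beyond the scatter). Compound 4 is expected to give about 32000 nM in this assay, between 12000 nM and 90000 nM, with a fair chance that only a limit is reported.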

Compound 4, half-maximal inhibitory concentration: > 40000 nM
Compound 4 gave a limit, no number; the forecaster's own chance of this, stated with the estimate: 35%; middle value at least 1.2-fold (0.09 log units) from the limit.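

In this assay, taking trifluoromethyl off this aromatic carbon and leaving hydrogen gives an at least 2.7-fold higher number from compound 3 to compound 4 (0.43 log units; beyond the scatter), so the bare phenyl does not keep the measurable number seen with 4-(trifluoromethyl)phenyl. Replacing the methoxy group of the 2-methoxyphenyl ring with hydrogen gives an at least 1.6-fold higher number from compound 2 to compound 4 (0.22 log units; that floor lies within the scatter), which is too small a floor to show that methoxy matters. The step between the chloro and hydrogen compounds cannot be read, so these two groups cannot be told apart here, as both compounds are reported only as a limit: the limit of > 40000 nM in this assay, at which 2 of the 4 values shown sit.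

Among the groups shown on this carbon, only trifluoromethyl gives a number, which leaves open whether it is special or whether a nitrile, a methyl group or an amine there would do the same. As far as these compounds go, how far compound 4 lies past its limit also remains open.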